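Taking one acetoxy group off compound 2

The compounds below may be only part of what the source reports. "The series", "measured", "known", "first", "only" and "open" are said of these compounds alone.

In a functional assay on cells (HCT cell line, Homo sapiens) for cytotoxicity (a lower number here means that less compound is needed, a higher number that more compound is needed for the effect), compound 2 (`CCCCC/C=C\C[C@@]1(O)C=C(Cl)C(=O)[C@@H]1[C@@H](OC(C)=O)[C@H](OC(C)=O)[C@H](CCCC(=O)OC)OC(C)=O`) gives 40 nM and so lies within the usual scatter of compound 3 (`CCCCC/C=C\C[C@@]1(O)C=C(Cl)C(=O)/C1=C\[C@H](C(C)=O)[C@H](CCCC(=O)OC)OC(C)=O`) at 32 nM while compound 1 (`CC/C=C/C/C=C\C[C@@]1(O)C=C(Cl)C(=O)/C1=C/[C@H](OC(C)=O)[C@H](CCCC(=O)OC)OC(C)=O`) at 320 nM stands apart from compound 2 by a gap beyond the scatter.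

The next compound to be tested is compound 4 (`CCCCC/C=C\C[C@@]1(O)C=C(Cl)C(=O)[C@@H]1C[C@H](OC(C)=O)[C@H](CCCC(=O)OC)OC(C)=O`). It differs from compound 2 in one place (hydrogen in place of acetoxy on a saturated chain carbon bound to a saturated chain carbon and a saturated ring carbon), with hydrogen in place of acetoxy on a saturated chain carbon bound to a saturated chain carbon and a saturated ring carbon.

Among the measured compounds shown here, no two tested compounds differ in just one place, so the data offer only indirect guidance. Set against compound 2, compound 3 carries fewer acetoxy groups, differs elsewhere too, and gives 32 nM so only a small step is expected in this assay, perhaps towards a higher number. Set against compound 2, compound 1 also carries fewer acetoxy groups and differs elsewhere too, yet compound 1 gives 320 nM so a larger rise cannot be ruled out.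

The estimated step of a 1.5-fold higher number from compound 2 to compound 4 (0.18 log units; within the scatter) is therefore modest and may not exceed the scatter. For compound 4 the expected value is 60 nM with an estimated range from 15 nM to 250 nM in repeated measurements.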

Compound 4, half-maximal effective concentration: 340 nM
Beside the measured number, compound 4's estimate is 5.7-fold (0.75 log units) below it; measured number outside the range, above it.
By their numbers in this assay, from the lowest: compounds 3 and 2 (each within the scatter of the next); then compounds 1 and 4 (each within the scatter of the next).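

In this assay, putting hydrogen in place of acetoxy on the saturated chain carbon bound to a saturated chain carbon and a saturated ring carbon gives an 8.5-fold higher number from compound 2 to compound 4 (0.93 log units; beyond the scatter). Among the compounds shown here, this is the first single-place comparison, and it shows that this position is not indifferent to what it carries: with the acetoxy gone, clearly more compound is needed for the cytotoxic effect. The change removes 4 heavy atoms and 2 hydrogen-bond acceptors together, and no accompanying measurement explains the step.

This one pair cannot show whether the effect depends on the whole acetoxy group, on its carbonyl or on the oxygen bound to the chain carbon. On these data alone, a hydroxyl group, a methoxy group or a fluorine atom at this same place would help separate these possibilities, while the effect of the same exchange on another core remains open.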